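The source may report more compounds than this note shows. Statements on the series, on what has been measured and on what is new or still open speak of the compounds shown alone.

Compound 2 `O=C(CCCCCCCC(=O)c1ccc(C(F)(F)F)cc1)NO` is a hydroxamic acid bearing a trifluoromethyl on its aromatic ring. For the measured compounds named here, in an assay on isolated protein for inhibition of histone deacetylase 8 (Homo sapiens) (on this read-out lower numbers stand for stronger inhibition and higher numbers for weaker inhibition), compound 2 gives 45 nM, the higher of the two numbers measured so far. Its nearest neighbour, compound 1 `COc1ccc(C(=O)CCCCCCCC(=O)NO)cc1` with a methoxy in that position, gives 15 nM; the step of a 3.0-fold higher number from compound 1 to compound 2 (0.48 log units; beyond the scatter) is the only one on record and shows that swapping this one group moves the number beyond the scatter. Compound 3 `O=C(CCCCCCCC(=O)c1ccc(Br)cc1)NO` carries the change (bromo in place of trifluoromethyl on an aromatic carbon). Going by the values given here, only the step to compound 2 bears on it, and a halogen is neither of the groups already tried, so compound 3 is expected to give about 30 nM, within 10 nM to 90 nM. The expected step of a 1.5-fold lower number from compound 2 to compound 3 (0.18 log units; within the scatter) is therefore small and near the scatter.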

Compound 3, half-maximal inhibitory concentration: 45 nM
Compound 3: middle estimate off by 1.5-fold (0.18 log units), on the low side; the measured number falls inside the stated range.
By their numbers in this assay, from the lowest: compound 1; then compounds 2 and 3 (each within the scatter of the next).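

Swapping trifluoromethyl, with four heavy atoms, for bromo, with one, gives no change at the digits printed from compound 2 to compound 3 (within the scatter) in this assay, so this difference in heavy atoms at this position leaves the number unchanged here. Methoxy now stands apart from two groups rather than one, with a 3.0-fold higher number from compound 1 to compound 3 (0.48 log units; beyond the scatter) matching the size of a 3.0-fold higher number from compound 1 to compound 2 (0.48 log units; beyond the scatter). No measured evidence accounts for either result. Still open, going by these compounds, is whether an amine or a carboxylic acid in this position would bring the number closer to that of compound 1, match compounds 2 and 3, or move it further away.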